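Swapping the Purine Nitrogen Substituent Toward a Sec-Butyl Chain

A few compounds are considered here, and "the series" means these few. Any claim that something is new, unique, unknown or untested is made for them only; others in the source may bear on it.

Measured compounds in a functional assay on NCI-H460 cells (Homo sapiens) for antiproliferative activity, read by CCK-8 assay, with a stated time of 72 h, tested at 8 uM; on this read-out higher numbers stand for a stronger effect at the one concentration tested and lower numbers for a weaker effect:
compound 1 `Nc1ccccc1NC(=O)/C=C/c1ccc(Cn2cnc3c(Nc4ccccc4)nc(Cl)nc32)cc1` gives 28.7%
compound 2 `Nc1ccccc1NC(=O)c1ccc(CNc2nc(Cl)nc3c2ncn3Cc2ccccc2)cc1` gives 46.4%
compound 3 `COC(CCn1cnc2c(NCc3ccc(C(=O)Nc4ccccc4N)cc3)nc(Cl)nc21)OC` gives 51.2%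

Among these three, compound 3 holds the highest number; its nearest neighbour is compound 2, whose number lies within the scatter of it, while compound 1 sits well below, beyond the scatter. Compound 4 `CCC(C)n1cnc2c(NCc3ccc(C(=O)Nc4ccccc4N)cc3)nc(Cl)nc21` differs from compound 3 only at the substituent on the aromatic nitrogen of the shared core: sec-butyl in place of 3,3-dimethoxypropyl on an aromatic nitrogen.

Among the compounds with values here, the one measured step that bears on this position is the exchange at the same nitrogen-bound chain that led from compound 2 to compound 3, which gave a number 4.8 percentage points higher from compound 2 to compound 3 (within the scatter). That earlier swap, though it exchanged quite different groups, did not move this assay beyond the scatter, so a step of similar modest size, in either direction or none at all, is expected here. Compound 4 is therefore estimated at 45% in this assay, within a range of 28% to 62%, which amounts to an expected step of a number 6.2 percentage points lower from compound 3 to compound 4 (within the scatter).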

Compound 4, a percentage reported as inhibition, at one concentration (the size of the read-out at that concentration, not a potency): 67.7%
Beside the measured number, compound 4's estimate is 22.7 percentage points below it; the measured number lies above the stated range.
By their numbers in this assay, from the lowest: compound 1; then compounds 2 and 3 (each within the scatter of the next); then compound 4.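

At the substituent on the aromatic nitrogen, the earlier exchange had stayed within the scatter, but in this assay the exchange of 3,3-dimethoxypropyl for sec-butyl gives a number 16.5 percentage points higher from compound 3 to compound 4 (beyond the scatter), and the exchange of benzyl for sec-butyl gives a number 21.3 percentage points higher from compound 2 to compound 4 (beyond the scatter). This position can therefore shift the read-out, and sec-butyl, with no ring and no hydrogen-bond acceptors, stands clear of both larger groups, one with a ring and one with acceptors. Nothing measured here accounts for these steps.

The compounds shown leave open whether the branch of sec-butyl counts, which an unbranched butyl chain or a cyclopentyl ring on the same nitrogen would address. They also leave open how a chain ending in an amine or a carboxylic acid would read in this assay.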